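Benzyloxy in place of isopropoxy on the shared core

The compounds below may be only part of what the source reports. "The series", "measured", "known", "first", "only" and "open" are said of these compounds alone.

Among the measured compounds shown here, compound 3 `CC(C)Oc1nc(C(C)(C)C)ccc1CNC(=O)C(C)c1ccc(NS(C)(=O)=O)c(F)c1` gives 2.3 nM in an assay on cells for antagonist activity at transient receptor potential cation channel subfamily V member 1 (Homo sapiens), read by FLIPR and calcium flux, with a stated time of 6 min (a lower number here means a stronger inhibitor, a higher number a weaker inhibitor), the highest of the three numbers so far. Compound 1 `CC(C(=O)NCc1ccc(C(C)(C)C)nc1N1CCCC1)c1ccc(NS(C)(=O)=O)c(F)c1` gives 1.2 nM and compound 2 `CCCCOc1nc(C(C)(C)C)ccc1CNC(=O)C(C)c1ccc(NS(C)(=O)=O)c(F)c1` gives 0.9 nM; the gap a 1.9-fold higher number from compound 1 to compound 3 (0.28 log units; within the scatter) is within the scatter, whereas a 2.6-fold higher number from compound 2 to compound 3 (0.41 log units; beyond the scatter) is beyond it. Compound 4 `CC(C(=O)NCc1ccc(C(C)(C)C)nc1OCc1ccc(F)cc1)c1ccc(NS(C)(=O)=O)c(F)c1` carries 4-fluorobenzyl in place of isopropyl on an oxygen on an aromatic ring. For the measured compounds named here, only one measured step changes the group on that oxygen, a 2.6-fold higher number from compound 2 to compound 3 (0.41 log units; beyond the scatter), in which butyl went with the lower number. Going by the values given here, no measured step covers a 4-fluorobenzyl at this position, so a modest drop, of about the size seen with compound 2, is expected rather than anything larger. Compound 4 is estimated at 1.2 nM, with a range of 0.4 nM to 3.5 nM, corresponding to an expected step of a 1.9-fold lower number from compound 3 to compound 4 (0.28 log units; within the scatter).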

Compound 4, inhibition constant: 0.8 nM
For compound 4 the middle estimate is 1.5-fold (0.18 log units) above the measured one, within the range that was stated.
By their numbers in this assay, from the lowest: compounds 4, 2, 1 and 3 (each within the scatter of the next, the first and the last beyond it).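

A six-membered aromatic ring is accepted on this oxygen: in this assay the change to 4-fluorobenzyl gives a 2.9-fold lower number from compound 3 to compound 4 (0.46 log units; beyond the scatter), a step of modest size. Against the butoxy group the ring makes no readable difference, at a 1.1-fold lower number from compound 2 to compound 4 (0.05 log units; within the scatter), and the same holds against pyrrolidin-1-yl on the aromatic carbon, at a 1.5-fold lower number from compound 1 to compound 4 (0.18 log units; within the scatter), so among the groups on this oxygen, isopropyl alone stands apart. No supporting data bear on the cause of this result. Going by these compounds, what the fluorine contributes stays open, as does how unsubstituted benzyl, a hexyl chain or a chain ending in a carboxylic acid would behave on this oxygen.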